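This account rests on a few compounds, and the source may have more. Where it says the series, first, only, none or still open, it means among the compounds named here.

Series notes. For the measured compounds named here, in a functional assay on B16-F10 cells (Mus musculus) for antiproliferative activity, read by MTT assay, with a stated time of 48 h (on this read-out lower numbers stand for stronger inhibition and higher numbers for weaker inhibition), compound 1 `COc1ccc(/C=C/c2cc(OC)cc(OC)c2/C=C/C(=O)c2ccc(C(F)(F)F)cc2)cc1` gives 4.3 ug/mL, and compound 2 `COc1ccc(/C=C/c2cc(OC)cc(OC)c2/C=C/C(=O)c2ccc(C)c(C)c2)cc1` gives 1.4 ug/mL, the lowest of the two numbers so far. Going by the values given here, the one step on hand, a 3.1-fold lower number from compound 1 to compound 2 (0.49 log units; beyond the scatter), turns on the group at the carbonyl carbon. Compound 3 `COc1ccc(/C=C/c2cc(OC)cc(OC)c2/C=C/C(=O)c2ccc(F)cc2)cc1` carries 4-fluorophenyl in place of 3,4-dimethylphenyl on a carbonyl carbon. The leaving group of compound 1 and the entering group of compound 3 both hold fluorine, so a partial return toward the number of compound 1 is expected, smaller than a 3.1-fold lower number from compound 1 to compound 2 (0.49 log units; beyond the scatter). For compound 3 the expected step is a 2.0-fold higher number from compound 2 to compound 3 (0.30 log units; within the scatter). The estimate for compound 3 in this assay is 2.8 ug/mL, ranging from 1.2 ug/mL to 6.5 ug/mL.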

Compound 3, half-maximal inhibitory concentration: 5.3 ug/mL
Compound 3: the middle estimate sits 1.9-fold (0.28 log units) below what was measured; low and high end bracket the measured number.
By their numbers in this assay, from the lowest: compound 2; then compounds 1 and 3 (each within the scatter of the next).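

In this assay the step (a 3.8-fold higher number from compound 2 to compound 3 (0.58 log units; beyond the scatter)) sets the 3,4-dimethylphenyl on the carbonyl carbon apart from a second aryl group, not only from the 4-(trifluoromethyl)phenyl. The step (a 1.2-fold higher number from compound 1 to compound 3 (0.09 log units; within the scatter)) does not separate fluoro from trifluoromethyl on the aromatic carbon, so among these three compounds only compound 2 stands apart. Nothing on hand bears on why the number changes. Open, from the compounds shown here alone, is whether both methyl groups of the 3,4-dimethylphenyl are needed for the lower number, and where a methoxy or an amine on that ring would fall.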